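The source may report more compounds than this note shows. Statements on the series, on what has been measured and on what is new or still open speak of the compounds shown alone.

Measured in a functional assay on HepG2 cells (Homo sapiens) for inhibition, read by MTT assay, with a stated time of 24 h; a lower number here means a stronger inhibitor, a higher number a weaker inhibitor:
- Compound 1 `CC1(C)[C@H]2CC[C@]1(C)N(Cc1cn(-c3cccc(F)c3)nn1)C(=O)C2`: 80 nM
- Compound 2 `CC1(C)[C@H]2CC[C@]1(C)N(Cc1cn(-c3ccccc3Br)nn1)C(=O)C2`: 150 nM
- Compound 3 `CC1(C)[C@H]2CC[C@]1(C)N(Cc1cn(-c3ccccc3Cl)nn1)C(=O)C2`: 60 nM

Compound 3 is not separated from compound 1, as a 1.3-fold lower number from compound 1 to compound 3 (0.12 log units; within the scatter) shows. The only separation among the three is a 2.5-fold lower number from compound 2 to compound 3 (0.40 log units; beyond the scatter). Next is compound 4 `CC1(C)[C@H]2CC[C@]1(C)N(Cc1cn(-c3ccc(Br)cc3)nn1)C(=O)C2`: 4-bromophenyl in place of 2-chlorophenyl on an aromatic nitrogen, with 4-bromophenyl in place of 2-chlorophenyl on an aromatic nitrogen. The closest evidence is that chloro-to-bromo swap, read backwards, together with a 1.9-fold higher number from compound 1 to compound 2 (0.27 log units; within the scatter). Among the measured compounds shown here, no measured compound carries 4-bromophenyl, so the data do not cover that placement. A modest rise in this assay is therefore expected, with the expected step being a 2.0-fold higher number from compound 3 to compound 4 (0.30 log units; within the scatter). The estimate for compound 4 is 120 nM, within an expected range of 50 nM to 300 nM.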

Compound 4, half-maximal inhibitory concentration: 110 nM
For compound 4 the middle estimate is 1.1-fold (0.04 log units) above the measured one; measured number inside the range.
By their numbers in this assay, from the lowest: compounds 3, 1, 4 and 2 (each within the scatter of the next, the first and the last beyond it).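

In this assay the 4-bromophenyl group on the aromatic nitrogen is not separated from either other aryl group, with a 1.8-fold higher number from compound 3 to compound 4 (0.26 log units; within the scatter) and a 1.4-fold higher number from compound 1 to compound 4 (0.14 log units; within the scatter) both inside the scatter. Bromo placement now has a first reading, and a 1.4-fold lower number from compound 2 to compound 4 (0.13 log units; within the scatter) leaves 4-bromophenyl and 2-bromophenyl unseparated on this position. No measurement at hand bears on the reason for these steps. Still open, on these data alone, are phenyl groups carrying an amine or a carboxylic acid, and a longer chain in place of the phenyl.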